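The source may report more compounds than this note shows. Statements on the series, on what has been measured and on what is new or still open speak of the compounds shown alone.

In a functional assay on HeLa cells (Homo sapiens) for inhibition, with a stated time of 72 h (on this read-out lower numbers stand for an effect already at smaller amounts and higher numbers for an effect only at larger amounts of compound), compound 1 (`COc1cc(CNCc2ccncc2)ccc1OCc1ccc(Cl)c(Cl)c1`) gives 4000 nM, while compound 2 (`COc1cc(CNCc2ccc(C(=O)O)cc2)ccc1OCc1ccc(Cl)nc1`) stands without a number, its entry reading "nd(insoluble)" (no result reported). Compound 3 (`COc1cc(CNCC2CCCO2)ccc1OCc1ccc(Cl)nc1`) departs from compound 2 through one change, (oxolan-2-yl in place of 4-carboxyphenyl on a saturated chain carbon bound to an amine nitrogen), with oxolan-2-yl in place of 4-carboxyphenyl on a saturated chain carbon bound to an amine nitrogen. Compound 2 offers no number from which to measure this step. Within the data shown here, the only reference is compound 1 at 4000 nM, so a result in that region, with a small shift toward higher numbers in this assay, is expected. Compound 3 is estimated at 6000 nM, with an expected range of 1500 nM to 25000 nM.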

Compound 3, half-maximal effective concentration: 66000 nM
Compound 3: the middle estimate sits 11-fold (1.04 log units) below what was measured; the measured number lies above the stated range.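

Among these compounds, no step from compound 2 to compound 3 can be read, as compound 2 has no number. The compounds shown leave open how oxolan-2-yl compares with 4-carboxyphenyl at this place. Nothing further at hand bears on the result for compound 3.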